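Aromatic methoxy on the phenoxy ring: compound 3 to compound 4

The compounds below may be only part of what the source reports. "The series", "measured", "known", "first", "only" and "open" are said of these compounds alone.

Measured compounds in a functional assay on cells for inhibition, with Murine T-cell line (Mus musculus) as the target; on this read-out lower numbers stand for stronger inhibition and higher numbers for weaker inhibition:
compound 1 `CC[C@@H]1/C=C(\C)C[C@H](C)C[C@H](OC)[C@H]2O[C@@](O)(C(=O)C(=O)N3CCCC[C@H]3C(=O)O[C@H](/C(C)=C/[C@@H]3CC[C@@H](Oc4ccccc4)[C@H](OC)C3)[C@H](C)[C@@H](O)CC1=O)[C@H](C)C[C@@H]2OC` gives 5.4 nM
compound 2 `CC[C@@H]1/C=C(\C)C[C@H](C)C[C@H](OC)[C@H]2O[C@@](O)(C(=O)C(=O)N3CCCC[C@H]3C(=O)O[C@H](/C(C)=C/[C@@H]3CC[C@@H](O)[C@H](Oc4ccccc4)C3)[C@H](C)[C@@H](O)CC1=O)[C@H](C)C[C@@H]2OC` gives 3.2 nM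
compound 3 `CC[C@@H]1/C=C(\C)C[C@H](C)C[C@H](OC)[C@H]2O[C@@](O)(C(=O)C(=O)N3CCCC[C@H]3C(=O)O[C@H](/C(C)=C/[C@@H]3CC[C@@H](Oc4ccccc4)[C@H](O)C3)[C@H](C)[C@@H](O)CC1=O)[C@H](C)C[C@@H]2OC` gives 5.2 nM

Compound 3 stands second highest of the three numbers in this assay; compound 1 sits within the scatter of it, and compound 2 also sits within the scatter of it. The three values therefore form one cluster without any ordering that can be trusted.

Compound 4 `CC[C@@H]1/C=C(\C)C[C@H](C)C[C@H](OC)[C@H]2O[C@@](O)(C(=O)C(=O)N3CCCC[C@H]3C(=O)O[C@H](/C(C)=C/[C@@H]3CC[C@@H](Oc4ccc(OC)cc4)[C@H](O)C3)[C@H](C)[C@@H](O)CC1=O)[C@H](C)C[C@@H]2OC` is the unmeasured compound. It differs from compound 3 in one place: methoxy in place of hydrogen on an aromatic carbon.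

Going by the values given here, the only measured single-point step in the set is a 1.0-fold lower number from compound 1 to compound 3 (0.02 log units; within the scatter), a change on an oxygen on a saturated carbon, not on the aromatic ring. Among the compounds with values here, no measured pair adds a group to the phenoxy ring, so nothing bears directly on the step from compound 3 to compound 4. Within the data shown here, the one step that exists stayed within the scatter, and the three measured values all lie close together, so the working expectation for this assay is no step beyond the scatter in either direction.

Compound 4 is thus expected to give about 5.5 nM, in a range from 2 nM to 15 nM. The implied step is expected to be a 1.1-fold higher number from compound 3 to compound 4 (0.02 log units; within the scatter).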

Compound 4, half-maximal inhibitory concentration: 1.2 nM
Compound 4: the middle estimate sits 4.6-fold (0.66 log units) above what was measured, outside the stated range (below it).
By their numbers in this assay, from the lowest: compound 4; then compounds 2, 3 and 1 (each within the scatter of the next).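

In this assay, going by these compounds alone, the phenoxy ring turns out to be a place where a single change registers: methoxy in place of hydrogen on an aromatic carbon, para to a large group, gives a 4.3-fold lower number from compound 3 to compound 4 (0.64 log units; beyond the scatter) and is the first single-point step to clear the scatter. The only earlier single-point step, a 1.0-fold lower number from compound 1 to compound 3 (0.02 log units; within the scatter) and located on an oxygen on a saturated carbon, gave no such signal, so the phenoxy to 4-methoxyphenoxy change is the first one shown to move this read-out. Nothing available here bears on why this change is followed by a lower number.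

The compounds shown leave open whether the step belongs to methoxy itself or would also appear with another group at the same place, such as fluorine, a hydroxyl, an ethoxy chain or a dimethylamino group. They also leave open whether the same phenoxy to 4-methoxyphenoxy change would give a step of similar size on the phenoxy ring of compound 1 or compound 2, since a single pair carries this result.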